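A few compounds are considered here, and "the series" means these few. Any claim that something is new, unique, unknown or untested is made for them only; others in the source may bear on it.

Compound 1 `Nc1ccccc1NC(=O)c1ccc(CSc2cccc(F)c2)cc1`: 3900 nM
Compound 2 `Nc1ccccc1NC(=O)c1ccc(CSCCc2ccccc2)cc1`: 2860 nM

In a functional assay on A-375 cells (Homo sapiens) for antiproliferative activity, read by CCK-8 assay, with a stated time of 72 h (a lower number here means a stronger inhibitor, a higher number a weaker inhibitor), compound 2 gives 2860 nM, which lies within the scatter of the value for compound 1, so the two cannot be told apart. The next compound, compound 3 `Cc1cc(C)cc(SCc2ccc(C(=O)Nc3ccccc3N)cc2)c1`, differs from compound 2 by one change: 3,5-dimethylphenyl in place of phenethyl on a sulfur. In words, 3,5-dimethylphenyl takes the place of phenethyl on a sulfur. For the measured compounds named here, one measured step bears on this: a 1.4-fold lower number from compound 1 to compound 2 (0.13 log units; within the scatter), phenethyl in place of 3-fluorophenyl on a sulfur. That swap stayed within the scatter, so no step beyond the scatter is expected in this assay. Going by the values given here, no measured compound carries 3,5-dimethylphenyl, so the range is kept wide. The expected step is a 1.2-fold higher number from compound 2 to compound 3 (0.06 log units; within the scatter). For compound 3 the estimated value is 3300 nM, with an expected range from 1500 nM to 7500 nM.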

Compound 3, half-maximal inhibitory concentration: 3670 nM
For compound 3 the middle estimate is 1.1-fold (0.05 log units) below the measured one, within the range that was stated.
By their numbers in this assay, from the lowest: compounds 2, 3 and 1 (each within the scatter of the next).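

In this assay, 3,5-dimethylphenyl and phenethyl on the sulfur hold the same atoms joined differently, one group with its ring carrying two methyl groups and the other with its ring on a saturated chain. That rearrangement gives a 1.3-fold higher number from compound 2 to compound 3 (0.11 log units; within the scatter), so it produces no readable difference at this position. The comparison with 3-fluorophenyl gives a 1.1-fold lower number from compound 1 to compound 3 (0.03 log units; within the scatter), which means that all three groups now sit within the scatter of one another, and no information is available to explain this.

All three groups are built on a carbon-only aromatic ring and carry no charge. On these data alone, it remains open whether an amine, a carboxylic acid or a longer chain at this position would move the number beyond the scatter.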